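Replacing phenyl with pyridin-2-yl in compound 1

This account rests on a few compounds, and the source may have more. Where it says the series, first, only, none or still open, it means among the compounds named here.

Three related compounds have been measured in a functional assay on HeLa cells (Homo sapiens) for cytotoxicity, read by WST assay, with a stated time of 48 h; a higher number here means a weaker inhibitor, a lower number a stronger inhibitor. Compound 1 `O[C@@H](c1ccccc1)[C@H]1CO[C@H](c2ccccc2)[C@@H](C/C=C/c2ccccc2)C1` gives 6060 nM, the lowest of the numbers available. The nearest, compound 2 `COc1ccc(/C=C/C[C@@H]2C[C@@H]([C@@H](O)c3ccc(OC)c(OC)c3)CO[C@H]2c2ccc(OC)c(OC)c2)cc1`, gives 17100 nM, a higher number by a margin beyond the scatter. Compound 3 `COc1ccc(/C=C/C[C@@H]2C[C@@H]([C@@H](OC(C)=O)c3ccc(OC)c(OC)c3)CO[C@H]2c2ccc(OC)c(OC)c2)cc1OC` is reported as > 100000 nM, which is a limit of the assay and not a number.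

The next compound, compound 4 `O[C@@H](c1ccccc1)[C@H]1CO[C@H](c2ccccc2)[C@@H](C/C=C/c2ccccn2)C1`, keeps the core of compound 1 and changes a single group. pyridin-2-yl in place of phenyl on a double-bonded chain carbon bound to a double-bonded chain carbon In words, pyridin-2-yl stands in place of phenyl on a double-bonded chain carbon bound to a double-bonded chain carbon, so that 3-phenylprop-2-en-1-yl becomes 3-(pyridin-2-yl)prop-2-en-1-yl.

Within the data shown here, no measured pair in this set differs in one place alone, so no direct precedent exists for the size of this step. The forecast is therefore anchored on compound 1 at 6060 nM, and only a small move towards a higher number in this assay is expected, one that stays within the scatter. The estimated step is a 1.7-fold higher number from compound 1 to compound 4 (0.22 log units; within the scatter). For compound 4 the expected value is 10000 nM, with an estimated range from 4000 nM to 30000 nM.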

Compound 4, half-maximal inhibitory concentration: 33800 nM
Estimate against measurement, compound 4: 3.4-fold (0.53 log units) below; measured number outside the range, above it.
By their numbers in this assay, from the lowest: compound 1; then compounds 2 and 4 (each within the scatter of the next). At a limit, above all of these: compound 3.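

In this assay, among these compounds, the replacement of phenyl by pyridin-2-yl on a double-bonded chain carbon bound to a double-bonded chain carbon gives the first step in this set that can be read at a single place: a 5.6-fold higher number from compound 1 to compound 4 (0.75 log units; beyond the scatter). Compounds 2 and 3 differ from compound 1 in more than one place and could not show this, whereas here the number moves beyond the scatter although the entering ring has the same number of heavy atoms as phenyl and differs in carrying a nitrogen and a hydrogen-bond acceptor. The position is therefore sensitive to this change in this assay, but nothing given here accounts for the size of the step.

The compounds shown leave open whether the step belongs to ring nitrogen as such or to its placement, as pyridin-3-yl or pyridin-4-yl in the same spot could tell. They also leave open whether an amine or a methoxy group on the phenyl of the core of compound 1 would move the number in the same direction, since this single step gives only one direction at one place.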